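This account rests on a few compounds, and the source may have more. Where it says the series, first, only, none or still open, it means among the compounds named here.

The three measured compounds share one core and differ only in the group on the saturated chain carbon bound to the oxygen on the aromatic ring. In an assay on cells with melanin-concentrating hormone receptor 1 (Homo sapiens) as the target, read by radioligand binding (on this read-out higher numbers stand for weaker inhibition and lower numbers for stronger inhibition), compound 1 `CCC(C)COc1cccc2ccc(N)nc12` gives 36 nM, and compound 2 `Nc1ccc2cccc(OCC3CCCC3)c2n1` gives 53 nM; the step of a 1.5-fold higher number from compound 1 to compound 2 (0.17 log units; within the scatter) stays within the scatter. Compound 3 `Nc1ccc2cccc(OCCC(F)(F)F)c2n1` gives 722 nM, the highest number of the three and thus the weakest inhibitor of the set, set apart by a 20-fold higher number from compound 1 to compound 3 (1.30 log units; beyond the scatter) and by a 14-fold higher number from compound 2 to compound 3 (1.13 log units; beyond the scatter). Compound 4 `CC1CC1COc1cccc2ccc(N)nc12` has not yet been measured in this assay. It differs from compound 3 by 2-methylcyclopropyl in place of 2,2,2-trifluoroethyl on a saturated chain carbon bound to an oxygen on an aromatic ring. The two large steps, one from sec-butyl and one from cyclopentyl to 2,2,2-trifluoroethyl, bear directly on this change, since compound 4 again carries a group of carbon only, with four heavy atoms like the sec-butyl of compound 1. The change is therefore expected to run the other way, with a large step in this assay, with the number coming down toward the values of compound 1 and compound 2. The expected step is a 12-fold lower number from compound 3 to compound 4 (1.08 log units; beyond the scatter). Compound 4 is estimated at 60 nM, with a range from 20 nM to 200 nM.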

Compound 4, half-maximal inhibitory concentration: 1640 nM
Compound 4: the middle estimate sits 27-fold (1.44 log units) below what was measured, and the stated range ends below it.
By their numbers in this assay, from the lowest: compounds 1 and 2 (each within the scatter of the next); then compound 3; then compound 4.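

In this assay, replacing the 2,2,2-trifluoroethyl group with 2-methylcyclopropyl does not restore inhibition, as there is a 2.3-fold higher number from compound 3 to compound 4 (0.36 log units; beyond the scatter), which makes compound 4 the weakest inhibitor of the four. The earlier compounds shown here could suggest that only the fluorine-bearing group stood apart, but there is also a 46-fold higher number from compound 1 to compound 4 (1.66 log units; beyond the scatter) and a 31-fold higher number from compound 2 to compound 4 (1.49 log units; beyond the scatter), so a group of carbon only does not by itself give a low number at this place, and neither does a ring, since cyclopentyl and 2-methylcyclopropyl both carry one and lie far apart. Nothing available here explains why these closely related carbon groups differ so much.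

The compounds shown leave open whether the higher number goes with the three-membered ring or with the methyl on it, a question that a plain cyclopropyl or a cyclobutyl at this place would address. As far as these compounds go, how a longer chain, or a chain ending in an amine, would behave on the saturated chain carbon bound to the oxygen also remains open.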